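The compounds below may be only part of what the source reports. "The series", "measured", "known", "first", "only" and "open" are said of these compounds alone.

In a functional assay on K562 cells (Homo sapiens) for inhibition, read by sulforhodamine B assay, with a stated time of 48 h (on this read-out higher numbers stand for weaker inhibition of growth and lower numbers for stronger inhibition of growth), compound 1 `CC1(/C=C/c2ccccc2)C=CC(=O)O1` gives > 1000000 nM, which is a limit of the assay and not a number. Compound 2 `COc1ccc(/C=C/C2(C)C=CC(=O)O2)cc1OC` gives > 1000000 nM, again a limit. Compound 3 `CC1(/C=C/c2ccc(O)cc2)C=CC(=O)O1` gives > 1000000 nM, also a limit, so it has no exact place on the scale and sits level with the other two only as far as a limit can show. The evidence so far is thin: the limit of > 1000000 nM in this assay, at which 3 of the 3 values shown sit.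

The next compound, compound 4 `COc1ccc(/C=C/C2(C)C=CC(=O)O2)cc1`, changes compound 3 in one place: methyl in place of hydrogen on an oxygen on an aromatic ring. In words, methyl takes the place of hydrogen on an oxygen on an aromatic ring, turning hydroxy to methoxy. Within the data shown here, only one measured step bears on this, a step that the two limits leave unreadable from compound 1 to compound 3. That step adds the hydroxy, but it has no readable size and so points in no direction. None of the compounds in this assay has yet given a true number, so no step beyond the usual scatter is expected here. The expected change is a number no higher from compound 3 to compound 4 (the limit leaves the size open). Compound 4 is estimated at 1000000 nM, with an expected range from 400000 nM to 1000000 nM, and it will most likely be reported as a limit again.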

Compound 4, concentration for total growth inhibition: > 1000000 nM
Compound 4: only a limit was reported; the forecaster's own chance of this, stated with the estimate: 85%; the middle value lies on the limit itself.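

Compound 4 gives > 1000000 nM, again a limit of the assay and not a number. Its steps from compound 1, compound 2 and compound 3 therefore cannot be read. The compounds shown leave open whether any of these groups on the aromatic ring changes growth inhibition at all, since every value rests on the same limit: the limit of > 1000000 nM in this assay, at which 4 of the 4 values shown sit.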